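Carbonyl substituent swaps on a shared dihydropyrimidinone core

The source may report more compounds than this note shows. Statements on the series, on what has been measured and on what is new or still open speak of the compounds shown alone.

Measured so far:
compound 1 `CC1=C(C(=O)C2CC2)C(c2ccoc2)NC(=O)N1`: 1%
compound 2 `CC1=C(C(N)=O)C(c2ccoc2)NC(=O)N1`: 1%

In an assay on membranes from CHO cells for displacement of a labelled ligand from adenosine receptor A1 (Homo sapiens), read by scintillation counting, with a stated time of 60 min, tested at 1 uM (on this read-out higher numbers stand for more inhibition at the one concentration tested (going by the name of the read-out) and lower numbers for less inhibition), compound 1 gives 1% and compound 2 gives 1%. Among the measured compounds shown here, the step of no change at the digits printed from compound 1 to compound 2 (within the scatter) is the only measured step; it shows that replacing cyclopropyl by amino on the carbonyl carbon leaves the read-out unchanged, and compound 2 therefore stands level with compound 1, with essentially no inhibition at the concentration tested.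

Compound 3 `CCSC(=O)C1=C(C)NC(=O)NC1c1ccoc1` is the next compound to be measured. It differs from compound 2 as follows: ethylsulfanyl in place of amino on a carbonyl carbon. For the measured compounds named here, the one step that bears on this change, no change at the digits printed from compound 1 to compound 2 (within the scatter), sits on the same carbonyl carbon and was flat, and both measured compounds lie at the floor of the read-out. No step beyond the scatter is expected from compound 2 to compound 3. Compound 3 is therefore expected to give about 2%, within 0% to 12%. The expected step is a number 1 percentage points higher from compound 2 to compound 3 (within the scatter).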

Compound 3, a percentage reported as inhibition, at one concentration (the size of the read-out at that concentration, not a potency): 3%
Compound 3: middle estimate off by 1 percentage points, on the low side, and the stated range covers the measured number.
By their numbers in this assay, from the lowest: compounds 1, 2 and 3 (each within the scatter of the next).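

In this assay, the carbonyl carbon whose other neighbour is the double-bonded ring carbon now has a third substituent, and the read-out gives a number 2 percentage points higher from compound 2 to compound 3 (within the scatter) and a number 2 percentage points higher from compound 1 to compound 3 (within the scatter) with ethylsulfanyl in place. Ethylsulfanyl for amino removes the hydrogen-bond donor of amino and brings in sulfur, yet neither swap gives a step beyond the scatter, so all three substituents read alike at this place in the series. No measurement at hand offers an explanation for this result.

As far as these compounds go, it remains open whether any substituent on this carbonyl carbon can lift the read-out clear of these low values, for example an ethoxy group, a carboxylic acid or a longer chain on the sulfur. The other places on the shared core remain untouched by these three compounds.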